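Swapping dimethylamino for fluoro on a bis-amide antagonist

The compounds below may be only part of what the source reports. "The series", "measured", "known", "first", "only" and "open" are said of these compounds alone.

Compound 1, `CN(C)c1ccc(C(=O)N[C@H]2CCC[C@H](NC(=O)c3cccc(Cl)c3)C2)cc1`, was tested in a functional assay on HEK293 cells for antagonist activity at metabotropic glutamate receptor 5 (Homo sapiens), read by FLIPR and calcium flux (on this read-out lower numbers stand for stronger inhibition and higher numbers for weaker inhibition), and gave 473 nM. Among the two compounds with a number, compound 1 stands highest: its nearest neighbour, compound 2, `N#Cc1cccc(C(=O)N[C@@H]2CCC[C@@H](NC(=O)c3ccccn3)C2)c1`, gives 231 nM, a gap beyond the usual scatter. Compound 3, `COc1cccc(C(=O)NC2CCCC(NC(=O)c3ccccn3)C2)c1`, gives > 10000 nM in this assay; this is the limit of > 10000 nM in this assay, at which 1 of the 3 values shown sits, not a number. Going by the values given here, none of these three compounds differs from another in a single place, so no measured step exists to lean on.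

Compound 4, `O=C(N[C@H]1CCC[C@H](NC(=O)c2cccc(Cl)c2)C1)c1ccc(F)cc1`, is the untested partner of compound 1. The change is fluoro in place of dimethylamino on an aromatic carbon. The dimethylamino group leaves and the smaller fluoro group enters at the same aromatic carbon, para to a large group.

Among the compounds with values here, with no measured step of this kind available, compound 4 is expected to stay close to compound 1 in this assay, with a step of a 1.1-fold higher number from compound 1 to compound 4 (0.02 log units; within the scatter) that lies within the scatter in either direction. Compound 4 is therefore estimated at about 500 nM, most likely between 150 nM and 2000 nM.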

Compound 4, half-maximal inhibitory concentration: 194 nM
Estimate against measurement, compound 4: 2.6-fold (0.41 log units) above, and the stated range covers the measured number.
By their numbers in this assay, from the lowest: compounds 4 and 2 (each within the scatter of the next); then compound 1. At a limit, above all of these: compound 3.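

Going by these compounds alone, this is the first measured step at this position: in this assay, fluoro in place of dimethylamino gives a 2.4-fold lower number from compound 1 to compound 4 (0.39 log units; beyond the scatter), a modest change but one beyond the scatter. The aromatic carbon para to a large group therefore does not need the dimethylamino group to keep inhibition, and fluoro, with one heavy atom in place of three and no hydrogen-bond acceptor counted, does better here. Nothing measured among these compounds accounts for the size or direction of this step.

Still open, as far as these compounds go, is whether the gain belongs to fluoro itself or simply follows from the departure of dimethylamino. A hydrogen, a methyl group, a chlorine atom or a primary amine on the same carbon would help to separate those two readings.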